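From 2-chlorophenyl to 2,6-dibromophenyl on compound 2

This account rests on a few compounds, and the source may have more. Where it says the series, first, only, none or still open, it means among the compounds named here.

In an ADME assay on microsomes from liver (Rattus norvegicus) for metabolic stability, read by LC-MS, using NADPH, at 37 degrees C (a higher number here means that the compound lasts longer, a lower number that the compound disappears faster), compound 2 `Cc1oc(-c2ccccc2Cl)nc1CN1CCC(C(=O)NCCCN2C[C@H](C)C[C@H](C)C2)CC1` gives 0.25 h, the higher of the two actual numbers, while compound 1 `Cc1ccccc1-c1nc(CN2CCC(C(=O)NCCCN3CC(C)(C)CC(C)(C)C3)CC2)c(C)o1` gives 0.095 h. Compound 3 `Cc1ccccc1-c1nc(CN2CCC(C(=O)NCCCN3CCCCC3)CC2)c(C)o1` reads > 0.5 h, which is a limit of the assay and not a number. The change to compound 4 `Cc1oc(-c2c(Br)cccc2Br)nc1CN1CCC(C(=O)NCCCN2C[C@H](C)C[C@H](C)C2)CC1` is 2,6-dibromophenyl in place of 2-chlorophenyl on an aromatic carbon. Among the measured compounds shown here, the one measured step, an at least 5.2-fold higher number from compound 1 to compound 3 (0.72 log units; beyond the scatter), alters a different group, on a saturated chain carbon, so it gives no size for this change. No shift beyond the scatter in this assay is therefore expected, in either direction. The expected step, a 1.1-fold lower number from compound 2 to compound 4 (0.06 log units; within the scatter), is estimated to stay within the scatter. For compound 4 the estimate is 0.22 h, with an expected range from 0.1 h to 0.5 h.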

Compound 4, half-life: 0.035 h
Beside the measured number, compound 4's estimate is 6.3-fold (0.80 log units) above it; measured number below the stated range.
By their numbers in this assay, from the lowest: compound 4; then compound 1; then compound 2. At a limit, above all of these: compound 3.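

In this assay, 2,6-dibromophenyl in place of 2-chlorophenyl gives a 7.1-fold lower number from compound 2 to compound 4 (0.85 log units; beyond the scatter). Among the compounds shown here, the only earlier step changed a group on a saturated chain carbon, so this shows that the half-life also responds to a change on the aromatic carbon next to the ring nitrogen and next to the ring oxygen. Nothing measured here accounts for the size of this step. From the compounds shown here alone, what 2,6-dichlorophenyl or 2-bromophenyl would give stays open, and with it whether the second halogen or the bromine carries the step. Also open, going by these compounds, is how a pyridyl group would read at this place.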